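A few compounds are considered here, and "the series" means these few. Any claim that something is new, unique, unknown or untested is made for them only; others in the source may bear on it.

In a functional assay on RKO cells (Homo sapiens) for cytotoxicity, read by resazurin assay, with a stated time of 72 h (on this read-out higher numbers stand for weaker inhibition and lower numbers for stronger inhibition), compound 1 (`Cc1nccn1-c1csc(Nc2ccc(S(N)(=O)=O)cc2)n1`) gives > 100000 nM, which is a limit of the assay and not a number. Compound 2 (`Cc1nccn1-c1csc(Nc2ccccc2)n1`) gives > 100000 nM, which is also a limit, so its position is known only in this form. The two compounds share that limit: the limit of > 100000 nM in this assay, at which 2 of the 2 values shown sit. Among the measured compounds shown here, the only measured change between them is a step that the two limits leave unreadable from compound 1 to compound 2, and it offers no usable size.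

Compound 3 (`Cc1ccc(Nc2nc(-n3ccnc3C)cs2)cc1`) differs from compound 2 by one small change: methyl in place of hydrogen on an aromatic carbon. For the measured compounds named here, no measured step involves a methyl group, and the step to compound 2 shows no readable effect on this assay. No clear shift beyond the scatter is therefore expected, and a further limit is the likeliest result. The expected change is a number no higher from compound 2 to compound 3 (the limit leaves the size open). For compound 3 the estimated value is 100000 nM, with an expected range from 40000 nM to 150000 nM.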

Compound 3, half-maximal inhibitory concentration: > 100000 nM
Compound 3: only a limit was reported; the forecaster's own chance of this, stated with the estimate: 80%; the middle value lies on the limit itself.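

No step among compound 1, compound 2 and compound 3 can be read, because each result is a limit of the assay and not a number: the limit of > 100000 nM in this assay, at which 3 of the 3 values shown sit.

These compounds leave open which change, if any, would bring a readable value in this assay.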